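The source may report more compounds than this note shows. Statements on the series, on what has been measured and on what is new or still open speak of the compounds shown alone.

Compound 1 `CCCS(=O)(=O)Nc1ccc(Cl)c(C(=O)Nc2cnc3[nH]nc(OC)c3c2)c1F`, 99.1%; compound 2 `CCCS(=O)(=O)Nc1ccc(F)c(C(=O)Nc2cnc3[nH]cc(Br)c3c2)c1F`, 99.4%; compound 3 `CCCS(=O)(=O)Nc1ccc(F)c(C(=O)Nc2cnc3[nH]nc(C)c3c2)c1F`, 89.9%.

These values come from an ADME assay on a cell-free system (plasma, Mus musculus, strain CD-1) for protein binding. Compound 3 stands apart: its unbound fraction is the highest of the three, beyond the scatter from both compound 1 and compound 2, with compound 1 the nearer of the two. Compound 4 `CCCS(=O)(=O)Nc1ccc(F)c(C(=O)Nc2cnc3[nH]nc(OC)c3c2)c1F` has not been measured. It differs from compound 3 in one respect: methoxy in place of methyl on an aromatic carbon. Within the data shown here, no measured pair shows this single change alone; compound 1 also carries methoxy but differs from compound 3 in more than this one respect, so it only hints at the direction. In this assay a step of moderate size toward more binding is expected, a 2.5-fold lower unbound fraction from compound 3 to compound 4 (0.40 log units; beyond the scatter). Compound 4 is estimated at 96%, between 90% and 99%.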

Compound 4, plasma protein binding: 97.4%
Compound 4: middle estimate off by 1.5-fold (0.19 log units) (unbound fraction), on the high side; the range from low to high includes it.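

In this assay, among these compounds, methoxy in place of methyl on this aromatic carbon of the five-membered ring gives a 3.9-fold lower unbound fraction from compound 3 to compound 4 (0.59 log units; beyond the scatter) as the first reading of this change alone. With methoxy held fixed, fluoro in place of chloro on an aromatic carbon gives a 2.9-fold higher unbound fraction from compound 1 to compound 4 (0.46 log units; beyond the scatter) and so shows that the shared core's other site also moves binding. No evidence here accounts for either step. The compounds shown leave open how ethoxy or an amine would read on the same carbon, and whether the methoxy step holds with chloro in place of fluoro.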